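The source may hold more compounds than are shown below. What is called first, only, known or untested is meant among the compounds shown, and "the series" means these compounds.

Compound 1 `Cc1nn(C)cc1Nc1nc(N)c2c(C#N)c(N3CCC[C@H]3C)n(C)c2n1` is the starting point of this account. In an assay on isolated protein for inhibition of Leucine-rich repeat serine/threonine-protein kinase 2 variant G2019S (Homo sapiens), read by TR-FRET and LanthaScreen, with stated times of 50 min and 30 min, in the presence of a further agent that is not named here (a lower number here means a stronger inhibitor, a higher number a weaker inhibitor), compound 1 gives 30 nM, the lowest of the two single numbers recorded in this series. Compound 2 `Cc1cn(C)nc1Nc1cc2c(c(N)n1)c(C#N)c(N1CCC[C@H]1C)n2C`, which carries a different shared core arrangement, gives 1290 nM in this assay, a markedly higher number that lies beyond the scatter of the method relative to compound 1. Compound 3 `Cc1nn(C2CCOC2)cc1Nc1nc(N)c2c(C#N)c(N3CCC[C@H]3C)n(C)c2n1`, in which a tetrahydrofuranyl group replaces the methyl on the pyrazole nitrogen, gives 12 nM; 28 nM (2 entries) in this assay across its several entries; those entries the several entries of compound 3 in this assay, 12 nM; 28 nM (2 entries) show how far repeated measurements of one compound can spread.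

Compound 4 `C[C@@H]1CCCN1c1c(C#N)c2c(N)nc(Nc3cnn(C)c3)nc2n1C` has not yet been measured in this assay. It differs from compound 1 by hydrogen in place of methyl on an aromatic carbon. Among the compounds with values here, no pair of measured compounds differs in exactly this way, so the size of the step cannot be read from the numbers in hand. Given that the change is the removal of a single carbon from the pyrazole ring, the step is expected to be small, either within the scatter or a modest weakening at most. The number for compound 4 in this assay is therefore estimated at 45 nM, within a range from 15 nM to 130 nM, which corresponds to an expected step of a 1.5-fold higher number from compound 1 to compound 4 (0.18 log units; within the scatter).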

Compound 4, half-maximal inhibitory concentration: 5 nM
Compound 4: the middle estimate sits 9.0-fold (0.95 log units) above what was measured, and the stated range ends above it.
By their numbers in this assay, from the lowest: compound 4; then compound 1; then compound 2.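

Within the data shown here, the change from 1,3-dimethyl-1H-pyrazol-4-yl to 1-methyl-1H-pyrazol-4-yl gives a 6.0-fold lower number from compound 1 to compound 4 (0.78 log units; beyond the scatter) in this assay, and this is the first step that can be read at a single place. It shows that the methyl on this aromatic carbon is not needed for a low number in this assay, and that with hydrogen in its place, at the cost of one heavy atom, compound 4 is the stronger inhibitor of the pair. This step rests on a single entry for each compound, and the spread of repeated measurements can be judged from one example: the several entries of compound 3 in this assay, 12 nM; 28 nM (2 entries)

On these data alone, whether hydrogen at this carbon would give a step of similar size with the tetrahydrofuranyl group of compound 3 on the pyrazole nitrogen remains open. The compounds shown also leave open how this position would respond to a group other than methyl or hydrogen, such as fluorine, chlorine, an ethyl group or a methoxy group, so they give only one step here and no trend across groups.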